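A few compounds are considered here, and "the series" means these few. Any claim that something is new, unique, unknown or untested is made for them only; others in the source may bear on it.

Measured so far in a functional assay on U-937 cells (Homo sapiens) for antiproliferative activity, read by MTT assay, with a stated time of 24 h; on this read-out lower numbers stand for stronger inhibition and higher numbers for weaker inhibition:

- compound 1 `CCCCc1oc2ccccc2c1C(=O)c1ccc(OCC(N)=O)cc1`: 42200 nM
- compound 2 `CCCCc1oc2ccccc2c1C(=O)c1ccc(OCC(=O)NC(C)C)cc1`: 17500 nM
- compound 3 `CCCCc1oc2ccccc2c1C(=O)c1ccc(OCC(=O)Nc2ccccc2)cc1`: 25900 nM

Compound 3, at 25900 nM, lies within the scatter of both other compounds. The data show this as a 1.6-fold lower number from compound 1 to compound 3 (0.21 log units; within the scatter) and as a 1.5-fold higher number from compound 2 to compound 3 (0.17 log units; within the scatter). Only the remaining pair differs by more than the scatter, with a 2.4-fold lower number from compound 1 to compound 2 (0.38 log units; beyond the scatter).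

Compound 4 `CCCCc1oc2ccccc2c1C(=O)c1ccc(OCC(=O)Nc2cccc(OC)c2)cc1` keeps everything in compound 3 except for one change on the anilide ring: methoxy in place of hydrogen on an aromatic carbon, meta to a large group, turning phenyl into 3-methoxyphenyl (methoxy in place of hydrogen on an aromatic carbon). Within the data shown here, no measured step covers a substituent on this ring, so the evidence is indirect. The closest steps are the three exchanges on the amide-type nitrogen, and the largest of them, a 2.4-fold lower number from compound 1 to compound 2 (0.38 log units; beyond the scatter), is only modest. Replacing isopropyl with phenyl gave a 1.5-fold higher number from compound 2 to compound 3 (0.17 log units; within the scatter), which is within the scatter. In this assay a small change is therefore expected, with no firm direction. The expected move is a 1.1-fold lower number from compound 3 to compound 4 (0.05 log units; within the scatter), which would not stand out from the scatter. For compound 4 the estimated value is 23000 nM, with an expected range of 11000 nM to 46000 nM.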

Compound 4, half-maximal inhibitory concentration: 24200 nM
The estimate for compound 4 lay 1.1-fold (0.02 log units) below the measured number, and the stated range covers the measured number.
By their numbers in this assay, from the lowest: compounds 2, 4, 3 and 1 (each within the scatter of the next, the first and the last beyond it).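

In this assay, among these compounds, methoxy in place of hydrogen on an aromatic carbon, meta to a large group, turns phenyl into 3-methoxyphenyl and gives the first reading for a substituent on this ring (a 1.1-fold lower number from compound 3 to compound 4 (0.03 log units; within the scatter)); the step stays within the scatter, so at this position the added methoxy has no effect that can be told apart from it. Set against the two other groups on the amide-type nitrogen, 3-methoxyphenyl gives the same picture as phenyl, since the steps from isopropyl (a 1.4-fold higher number from compound 2 to compound 4 (0.14 log units; within the scatter)) and from hydrogen (a 1.7-fold lower number from compound 1 to compound 4 (0.24 log units; within the scatter)) also stay within the scatter. Nothing in the data explains this result.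

As far as these compounds go, whether this position stays as undemanding with a group other than methoxy remains open, for example an amine, a carboxylic acid or a longer chain ending in an ether oxygen. From the compounds shown here alone, it also remains open whether methoxy elsewhere on the same ring, or several such groups together, would produce a step that stands clear of the scatter.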